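The source may report more compounds than this note shows. Statements on the series, on what has been measured and on what is new or still open speak of the compounds shown alone.

In a functional assay on SK-BR-3 cells (Homo sapiens) for antiproliferative activity, read by CCK-8 assay, with a stated time of 72 h (a higher number here means a weaker inhibitor, a lower number a stronger inhibitor), three compounds sharing one core have been measured. Compound 1 `Cc1cc(Nc2cc(N3CCN(C)CC3)nc(Nc3ccc(S(N)(=O)=O)cc3)n2)n[nH]1` gives 15900 nM, compound 2 `Cc1cc(Nc2cc(N3CCN(C)CC3)nc(Nc3cccc([N+](=O)[O-])c3)n2)n[nH]1` gives 2180 nM, and compound 3 `Cc1cc(Nc2cc(N3CCN(C)CC3)nc(Nc3ccc(C#N)cc3)n2)n[nH]1` gives 883 nM, the lowest of the three numbers. The next compound, compound 4 `COc1ccc(Nc2nc(Nc3cc(C)[nH]n3)cc(N3CCN(C)CC3)n2)cc1`, carries methoxy in place of cyano on an aromatic carbon, para to a large group (methoxy in place of cyano on an aromatic carbon). The closest measured precedent is a change at that same place, an 18-fold lower number from compound 1 to compound 3 (1.26 log units; beyond the scatter), which is large. The steps that swap the whole aryl group are smaller: a 7.3-fold lower number from compound 1 to compound 2 (0.86 log units; beyond the scatter) and a 2.5-fold lower number from compound 2 to compound 3 (0.39 log units; beyond the scatter) are both modest. Among the measured compounds shown here, these steps show that the number in this assay can shift with this part of the structure, but none of the measured compounds carries methoxy. With compound 3 at 883 nM as the lowest of the three, a modest move to a higher number is expected rather than a further fall. The expected step is a 2.0-fold higher number from compound 3 to compound 4 (0.31 log units; beyond the scatter). For compound 4 the estimate is 1800 nM, with an expected range from 500 nM to 6000 nM.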

Compound 4, half-maximal inhibitory concentration: 14700 nM
Estimate against measurement, compound 4: 8.2-fold (0.91 log units) below; measured number above the stated range.
By their numbers in this assay, from the lowest: compound 3; then compound 2; then compounds 4 and 1 (each within the scatter of the next).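

In this assay, the swap at this aromatic carbon, para to a large group, proved to be a large change in its own right, a 17-fold higher number from compound 3 to compound 4 (1.22 log units; beyond the scatter), even though cyano and methoxy have the same count of heavy atoms and of hydrogen-bond acceptors. Methoxy also gave up the standing of the 4-cyanophenyl compound relative to the 3-nitrophenyl one, a 6.7-fold higher number from compound 2 to compound 4 (0.83 log units; beyond the scatter), and it did not separate from sulfamoyl, a 1.1-fold lower number from compound 1 to compound 4 (0.03 log units; within the scatter), so of the three groups at this carbon only cyano brought the number down. Nothing available accounts for this difference between the groups. The compounds shown leave open whether the low number is particular to cyano. An amine, a carboxylic acid or a chloro group at the same carbon could fall with cyano or with methoxy and sulfamoyl.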